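The source may report more compounds than this note shows. Statements on the series, on what has been measured and on what is new or still open speak of the compounds shown alone.

Compound 1 `COc1ccc(N(CC(=O)NCCCSc2ccccc2)C(=O)CCSC2=C(C)C(=O)c3ccccc3C2=O)cc1` and compound 2 `COc1ccc(N(CC(=O)NCCC[Se]c2ccccc2)C(=O)CCSC2=C(C)C(=O)c3ccccc3C2=O)cc1` share one core and differ only on a saturated chain carbon, three bonds along the chain from an amide-type nitrogen. In an ADME assay on cells (Fibroblast, Homo sapiens) for cytotoxicity, read by MTT assay, with a stated time of 24 h (on this read-out lower numbers stand for stronger inhibition and higher numbers for weaker inhibition), compound 2 gives 24000 nM. In this assay compound 1 gives 26000 nM. The change a group of 7 heavy atoms (6 carbon, 1 sulfur; one six-membered aromatic ring of carbon only) in place of a group of 7 heavy atoms (6 carbon, 1 selenium; one six-membered aromatic ring of carbon only), on a saturated chain carbon, three bonds along the chain from an amide-type nitrogen thus made a 1.1-fold higher number from compound 2 to compound 1 (0.03 log units; within the scatter).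

Compound 3 `COc1ccc(N(CC(=O)NCCC[Se]c2ccccc2)C(=O)C#Cc2ccccc2)cc1` carries a different core; how its core differs from that of compound 2 is not broken down here. In this assay compound 3 reaches only a limit of the assay, >= 100000 nM. That value is the limit of >= 100000 nM in this assay, at which 1 of the 3 values shown sits.

Compound 4 `COc1ccc(N(CC(=O)NCCCSc2ccccc2)C(=O)C#Cc2ccccc2)cc1` carries the same core as compound 3 and differs from it by the same change, (a group of 7 heavy atoms (6 carbon, 1 sulfur; one six-membered aromatic ring of carbon only) in place of a group of 7 heavy atoms (6 carbon, 1 selenium; one six-membered aromatic ring of carbon only), on a saturated chain carbon, three bonds along the chain from an amide-type nitrogen). The step the estimate means is a number no higher from compound 3 to compound 4 (the limit leaves the size open), expected to be small because the earlier step of a 1.1-fold higher number from compound 2 to compound 1 (0.03 log units; within the scatter) lay within the scatter. In this assay compound 4 is therefore estimated at 100000 nM, most likely again reported only as a limit, with a range from 50000 nM to 300000 nM.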

Compound 4, half-maximal inhibitory concentration: >= 100000 nM
Compound 4: a limit, no number (the forecaster's own chance of this, stated with the estimate: 80%); the middle value sits exactly at the limit.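

Within the data shown here, no step from compound 3 to compound 4 can be read, because both stand only as limits in this assay: the limit of >= 100000 nM in this assay, at which 2 of the 4 values shown sit.

The compounds shown leave open whether swapping the selenium-bearing group for phenylsulfanyl changes anything on the core of compound 3, and how far past the limit compound 3 and compound 4 lie.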